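A few compounds are considered here, and "the series" means these few. Any claim that something is new, unique, unknown or untested is made for them only; others in the source may bear on it.

In a functional assay on A549 cells (Homo sapiens) for cytotoxicity, read by MTT assay, with a stated time of 48 h (a higher number here means a weaker inhibitor, a lower number a stronger inhibitor), compound 1 `O=c1ccoc2cc(OCc3cn(Cc4ccc(Cl)cc4)nn3)ccc12` gives only a limit, > 100000 nM. Within the data shown here, compound 2 `O=c1ccoc2cc(OCc3cn(Cc4cccc(Cl)c4)nn3)ccc12` gives 13700 nM, the only actual number so far. Compound 3 `O=c1ccoc2cc(OCc3cn(Cc4ccccc4Cl)nn3)ccc12` follows from compound 2 by 2-chlorophenyl in place of 3-chlorophenyl on a saturated chain carbon bound to an aromatic nitrogen. Among the measured compounds shown here, the one measured step bearing on this is an at least 7.2-fold lower number from compound 1 to compound 2 (0.86 log units; beyond the scatter), which starts from a limit and shows that the chlorine position can matter. A modest move towards a higher number is therefore expected, an estimated 1.8-fold higher number from compound 2 to compound 3 (0.26 log units; within the scatter). Compound 3 is expected at 25000 nM, within an estimated range of 8000 nM to 80000 nM.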

Compound 3, half-maximal inhibitory concentration: > 100000 nM
Compound 3 ended at the assay's limit; the forecaster's own chance of this, stated with the estimate: 20%; at least 4.0-fold (0.60 log units) between middle value and limit.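

In this assay, 2-chlorophenyl in place of 3-chlorophenyl gives an at least 7.2-fold higher number from compound 2 to compound 3 (0.86 log units; beyond the scatter), so compound 2 now stands apart from both other chlorine placements shown, not from one alone. Compound 3, like compound 1, rests on a limit, so the step between them cannot be read and gives no order for 2-chlorophenyl and 4-chlorophenyl. The steps away from compound 2 therefore have only a lower bound on their size: the limit of > 100000 nM in this assay, at which 2 of the 3 values shown sit.

As far as these compounds go, what remains open is whether 3-methoxyphenyl, 3-aminophenyl or plain phenyl would keep a measurable value at this position.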